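A few compounds are considered here, and "the series" means these few. Any claim that something is new, unique, unknown or untested is made for them only; others in the source may bear on it.

In a functional assay on UO-31 cells (Homo sapiens) for inhibition, read by sulforhodamine B assay, with a stated time of 48 h (on this read-out lower numbers stand for higher toxicity in this test and higher numbers for lower toxicity in this test), compound 1 `COc1cc(-c2cc(/C=C/C(=O)c3ccc(N)cc3)[nH]n2)cc(OC)c1OC` gives 6000 nM, whereas compound 2 `COc1ccc(-c2cc(/C=C/C(=O)c3ccc(N)cc3)[nH]n2)cc1OC` gives 43200 nM. The change between them, (hydrogen in place of methoxy on an aromatic carbon), made a 7.2-fold higher number from compound 1 to compound 2 (0.86 log units; beyond the scatter). Compound 3 `COc1cc(C(=O)/C=C/c2cc(-c3cc(OC)c(OC)c(OC)c3)n[nH]2)cc(OC)c1OC` gives 5160 nM; how its core differs from the core of compound 1 is not broken down here. Compound 4 `COc1ccc(-c2cc(/C=C/C(=O)c3cc(OC)c(OC)c(OC)c3)[nH]n2)cc1OC` has not yet been measured. Relative to compound 3 it carries hydrogen in place of methoxy on an aromatic carbon, the same change at the same place as the one from compound 1 to compound 2. Compound 4 is therefore expected to give a higher number, with an estimated step of a 5.0-fold higher number from compound 3 to compound 4 (0.70 log units; beyond the scatter) set beside the earlier 7.2-fold higher number from compound 1 to compound 2 (0.86 log units; beyond the scatter), tempered slightly as it rests on a single precedent in a different core. Compound 4 is estimated at 26000 nM, expected to fall between 9000 nM and 75000 nM.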

Compound 4, concentration lethal to 50% of the cells: 5290 nM
Compound 4: the middle estimate sits 4.9-fold (0.69 log units) above what was measured, and the stated range ends above it.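

In this assay, replacing methoxy with hydrogen on the core of compound 3 amounts to a 1.0-fold higher number from compound 3 to compound 4 (0.01 log units; within the scatter), so this step stays within the scatter. The change therefore did not carry over with the same size from one core to the other: the same change on two cores in this assay, a 7.2-fold higher number (0.86 log units; beyond the scatter) from compound 1 to compound 2 and a 1.0-fold higher number (0.01 log units; within the scatter) from compound 3 to compound 4, 7.0-fold (0.85 log units) apart, beyond the scatter of two such steps. This shows that the size of the step differs between these two cores, but two pairs do not show which part of the cores accounts for the gap or what the change would do on a further core.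

The compounds shown leave open what a hydroxyl group, a fluorine atom or an ethoxy group would do at this place on either core. They also leave open whether the gap between the two steps would persist on other cells.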